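The compounds below may be only part of what the source reports. "The series", "measured", "known", "first", "only" and "open" are said of these compounds alone.

In an ADME assay on S9 fraction from liver (Rattus norvegicus) for metabolic stability, with a stated time of 1 h (on this read-out higher numbers stand for a more stable compound and lower numbers for a less stable compound), two compounds have been measured so far. Compound 1 `N#Cc1cnc(NCc2cnccc2C(F)(F)F)cc1N[C@H]1CC[C@H](O)CC1` gives 25%, and compound 2 `N#Cc1cnc(NCc2ccccc2C(F)(F)F)cc1N[C@H]1C[C@@H](C(N)=O)C1` gives 83%, the higher of the two numbers and beyond the scatter from compound 1. Within the data shown here, these two compounds differ in more than one place, so no step between measured compounds shows the effect of a single change. Compound 3 `N#Cc1cnc(NCc2ccccc2C(F)(F)F)cc1N[C@H]1CC[C@@H](C(N)=O)CC1` has not yet been measured and differs from compound 2 in one place: 4-carbamoylcyclohexyl in place of 3-carbamoylcyclobutyl on a nitrogen on an aromatic ring. A downward step beyond the scatter is expected, resting only on compound 1 at 25%, which also carries a six-membered non-aromatic ring of carbon only on that nitrogen. The expected change is a number 23 percentage points lower from compound 2 to compound 3 (beyond the scatter). In this assay, the estimate for compound 3 is 60%, with an expected range from 35% to 85%.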

Compound 3, percent of the compound remaining: 3%
Compound 3: the middle estimate sits 57 percentage points above what was measured; measured number below the stated range.
By their numbers in this assay, from the lowest: compound 3; then compound 1; then compound 2.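

In this assay, among these compounds, putting 4-carbamoylcyclohexyl in place of 3-carbamoylcyclobutyl on a nitrogen on an aromatic ring gives a number 80 percentage points lower from compound 2 to compound 3 (beyond the scatter) and is the first step here that isolates a single change. The two groups match in their counts of hydrogen-bond donors and acceptors and in net charge, and they differ in a four-membered against a six-membered ring of carbon only, so this position is highly sensitive to the exchange of one group for the other. No measurement shown explains why the number falls so far.

On these data alone, it remains open whether a cyclopentyl ring carrying the same carbamoyl group would sit nearer to compound 2 or to compound 3. It is also unknown whether a carboxylic acid in place of the carbamoyl group on the six-membered ring would change the result.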